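A few compounds are considered here, and "the series" means these few. Any claim that something is new, unique, unknown or untested is made for them only; others in the source may bear on it.

Compound 1 `Cc1nc(N)c2c(-c3ccccc3)cn([C@@H]3O[C@H](CO)[C@@H](O)[C@H]3O)c2n1` gives in a functional assay on HL-60 cells (Homo sapiens) for antiproliferative activity, read by XTT assay, with a stated time of 72 h (on this read-out lower numbers stand for stronger inhibition and higher numbers for weaker inhibition), only a limit of the assay, > 20000 nM.
Compound 2 `C#Cc1cn([C@@H]2O[C@H](CO)[C@@H](O)[C@H]2O)c2nc(C)nc(N)c12` gives in this assay likewise only a limit, > 20000 nM.
Compound 3 `COc1ncnc2c1c(-c1ccccc1)cn2[C@@H]1O[C@H](CO)[C@@H](O)[C@H]1O` gives in this assay also only a limit, > 20000 nM.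

The change from compound 1 to compound 2 is ethynyl in place of phenyl on an aromatic carbon. The size of its step, a step that the two limits leave unreadable from compound 1 to compound 2, cannot be read, because of the limit of > 20000 nM in this assay, at which 3 of the 3 values shown sit. Compound 4 `C#Cc1cn([C@@H]2O[C@H](CO)[C@@H](O)[C@H]2O)c2ncnc(OC)c12` has not yet been measured; it arises from compound 3 by ethynyl in place of phenyl on an aromatic carbon, the same change at the same place as from compound 1 to compound 2. How the core of compound 3 differs from that of compound 1 is not broken down here. Because every value shown sits at the limit of > 20000 nM in this assay, at which 3 of the 3 values shown sit, the step expected in this assay is a step that the limit leaves unreadable from compound 3 to compound 4, with no readable change. Compound 4 is therefore expected at 30000 nM, most likely reported again only as a limit.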

Compound 4, half-maximal inhibitory concentration: 190 nM
For compound 4 the middle estimate is 160-fold (2.20 log units) above the measured one; measured number outside the range, below it.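

In this assay, ethynyl in place of phenyl on the core of compound 3 gives an at least 100-fold lower number from compound 3 to compound 4 (2.02 log units; beyond the scatter), a large step beyond the usual scatter, so on this core the change has a strong effect. On the core of compound 1, the same change leaves compound 2 with only a limit of the assay, > 20000 nM. The step there cannot be read, so the data neither show that the gain carries over to that core nor rule it out, because the values on both sides of that step are limits: the limit of > 20000 nM in this assay, at which 3 of the 4 values shown sit.

What the compounds shown leave open is how specific the gain is to ethynyl. A nitrile or a longer chain on the same aromatic carbon could give a similar or a different value.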